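The compounds below may be only part of what the source reports. "The series", "measured", "known", "first", "only" and "open" are said of these compounds alone.

Working notes on the series, read in a functional assay on LNCaP cells (Homo sapiens) for antiproliferative activity, read by MTT assay, with a stated time of 3 days; on this read-out higher numbers stand for weaker inhibition and lower numbers for stronger inhibition. Compound 1 `CCS(=O)(=O)Nc1ccc(-c2cc(=O)c3c(O)cc(OC)c(OC(C)C)c3o2)cc1` gives 113000 nM, compound 2 `CCCS(=O)(=O)Nc1ccc(-c2cc(=O)c3c(O)cc(OC)c(OC(C)C)c3o2)cc1` gives 30500 nM, and compound 3 `C=CC(=O)Nc1ccc(-c2cc(=O)c3c(O)cc(OC)c(OC(C)C)c3o2)cc1` gives 15100 nM, the lowest of the three numbers. Next comes compound 4 `COc1cc(O)c2c(=O)cc(-c3ccc(NC(=O)NC4CC4)cc3)oc2c1OC(C)C`, which differs from compound 3 as follows: cyclopropylamino in place of vinyl on a carbonyl carbon. In words, cyclopropylamino stands in place of vinyl on a carbonyl carbon whose other neighbour is an amide-type nitrogen.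

Among the compounds with values here, no measured step makes this exchange. The nearest evidence comes from changes to the group on a nitrogen on an aromatic ring: a 7.5-fold lower number from compound 1 to compound 3 (0.87 log units; beyond the scatter) and a 2.0-fold lower number from compound 2 to compound 3 (0.31 log units; beyond the scatter), both modest. The chain extension on the sulfonyl side, a 3.7-fold lower number from compound 1 to compound 2 (0.57 log units; beyond the scatter), is also modest. Changes in this part of the series have therefore moved the number, but only by modest steps. Compound 1 and compound 2 carry sulfonyl groups, so neither shows what a change on the carbonyl carbon does.

A step beyond the scatter in this assay is not expected, with a slight lean towards a higher number. The expected step is a 1.3-fold higher number from compound 3 to compound 4 (0.12 log units; within the scatter). Compound 4 is estimated at 20000 nM, with an expected range of 6500 nM to 60000 nM.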

Compound 4, half-maximal inhibitory concentration: 13800 nM
For compound 4 the middle estimate is 1.4-fold (0.16 log units) above the measured one; measured number inside the range.
By their numbers in this assay, from the lowest: compounds 4 and 3 (each within the scatter of the next); then compound 2; then compound 1.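

In this assay, a change on the carbonyl carbon can now be read directly: cyclopropylamino in place of vinyl gives a 1.1-fold lower number from compound 3 to compound 4 (0.04 log units; within the scatter), so the number does not depend on keeping the vinyl group and its double bond, and it tolerates a larger group with a three-membered ring at this place. The new compound also shows that the gap to the sulfonyl compounds is not confined to vinylcarbonyl, since cyclopropylcarbamoyl on the nitrogen gives a 2.2-fold lower number from compound 2 to compound 4 (0.34 log units; beyond the scatter) and an 8.2-fold lower number from compound 1 to compound 4 (0.91 log units; beyond the scatter), both modest and close in size to the steps already seen for vinylcarbonyl. No supporting measurement is available to explain why the two carbonyl-linked groups read alike.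

The compounds shown leave open how far this tolerance extends on the carbonyl carbon, for example to a saturated ethyl group, a dimethylamino group or a longer alkylamino chain. An open-chain ethylamino group would also help separate the contribution of the amino nitrogen from that of the three-membered ring, which enter together in this exchange.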